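The source may hold more compounds than are shown below. What is called first, only, known or untested is meant among the compounds shown, and "the series" means these compounds.

Measured so far in an ADME assay on the whole organism (blood, Mus musculus, strain C57BL/6) for pharmacokinetics, read by HPLC, with a stated time of 4 h, at a dose of 2 mg/kg by the intraperitoneal route; a higher number here means more compound in the circulation at the dose given, a lower number less compound in the circulation:
- compound 1 `O=C(Nc1ccc(Cl)c(C(=O)N2CCCCC2)c1O)Nc1cccc(F)c1Cl`: "below limit of detection" (no number reported)
- compound 2 `CC(C)S(=O)(=O)c1c(Cl)ccc(NC(=O)Nc2cccc(Cl)c2Cl)c1O`: 290 ng.h/mL
- compound 3 `CC(C)N1CCN(S(=O)(=O)c2c(Cl)ccc(NC(=O)Nc3cccc(F)c3Cl)c2O)CC1`: 52.9 ng.h/mL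

Compound 1 has no number on this scale: its result is "below limit of detection" (no number reported). Compound 2 gives 290 ng.h/mL and compound 3 gives 52.9 ng.h/mL, but each differs from compound 1 in more than one place, so neither pair isolates a single change.

Compound 4 `O=C(Nc1ccc(Cl)c(C(=O)N2CCCC2)c1O)Nc1cccc(F)c1Cl` is still to be measured. The change from compound 1 is pyrrolidin-1-yl in place of piperidin-1-yl on a carbonyl carbon. For the measured compounds named here, no measured pair shows this change, so the data give no direction for it. A small step in this assay is expected, and compound 4 should stay low in the series. A second result without a number would not be surprising. Any number is expected to lie nearer compound 3 at 52.9 ng.h/mL than compound 2 at 290 ng.h/mL.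

For compound 4 the estimated value is 45 ng.h/mL, with an expected range of 10 ng.h/mL to 200 ng.h/mL.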

Compound 4, area under the concentration-time curve: "below limit of detection" (no number reported)
The entry for compound 4 holds no number; there is nothing to compare the estimate with.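

Compound 1 and compound 4 both lack a number in this assay, so no step can be read for pyrrolidin-1-yl in place of piperidin-1-yl. The compounds shown leave open how these two groups compare on this carbonyl carbon. No evidence bears on this result.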